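Swapping 3-bromophenyl for pyridin-4-yl on compound 3

A few compounds are considered here, and "the series" means these few. Any claim that something is new, unique, unknown or untested is made for them only; others in the source may bear on it.

compound 1 `CC(C)=CCC/C(C)=C/CC/C(C)=C/CC[C@@H]1[C@@]2(C)CC/C(=N\OCc3cn(-c4ccccc4)nn3)C(C)(C)[C@@H]2CC[C@@]1(C)O` gives 9590 nM
compound 2 `CC(C)=CCC/C(C)=C/CC/C(C)=C/CC[C@@H]1[C@@]2(C)CC/C(=N\OCc3cn(-c4cccc(Br)c4)nn3)C(C)(C)[C@@H]2CC[C@@]1(C)O` gives 24800 nM
compound 3 `CC(C)=CCC/C(C)=C/CC/C(C)=C/CC[C@@H]1[C@@]2(C)C/C(=C\c3ccc(OCc4cn(-c5cccc(Br)c5)nn4)cc3)C(=O)C(C)(C)[C@@H]2CC[C@@]1(C)O` gives 61000 nM
compound 4 `CC(C)=CCC/C(C)=C/CC/C(C)=C/CC[C@@H]1[C@@]2(C)C/C(=C\c3ccc(OCc4cn(-c5ccncc5)nn4)cc3)C(=O)C(C)(C)[C@@H]2CC[C@@]1(C)O` has no value yet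

In a functional assay on MCF7 cells (Homo sapiens) for cytotoxicity, read by MTT assay, with a stated time of 48 h (on this read-out higher numbers stand for weaker inhibition and lower numbers for stronger inhibition), compound 3 stands highest of the three measured compounds, with compound 2 nearest and compound 1 furthest. Going to compound 4 brings pyridin-4-yl in place of 3-bromophenyl on an aromatic nitrogen as the only change. Among the compounds with values here, one measured step bears on this, and only partly: a 2.6-fold higher number from compound 1 to compound 2 (0.41 log units; beyond the scatter) came with bromo in place of hydrogen on an aromatic carbon, a modest rise. Pyridin-4-yl itself has no measured step. Read backward for the departing bromine, that rise gives an expected modest fall, with a 2.0-fold lower number from compound 3 to compound 4 (0.31 log units; beyond the scatter) as the estimated step. Compound 4 is estimated at 30000 nM within 12000 nM to 75000 nM for now.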

Compound 4, half-maximal inhibitory concentration: 37500 nM
Estimate against measurement, compound 4: 1.3-fold (0.10 log units) below; the measured number falls inside the stated range.
By their numbers in this assay, from the lowest: compound 1; then compounds 2, 4 and 3 (each within the scatter of the next, the first and the last beyond it).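

In this assay, the change shows a 1.6-fold lower number from compound 3 to compound 4 (0.21 log units; within the scatter) with pyridin-4-yl in place of 3-bromophenyl on an aromatic nitrogen. This position therefore takes a six-membered aromatic ring with 1 hetero atom and no bromine, with no step beyond the scatter. No available measurement accounts for this result.

Open: whether a morpholine, an amine or a carboxylic acid on this aromatic nitrogen would separate from compound 3. Also open, from the compounds shown here alone, is how pyridin-4-yl reads on the core of compound 1.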